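The source may hold more compounds than are shown below. What is called first, only, known or untested is meant among the compounds shown, and "the series" means these compounds.

In a functional assay on Caco-2 cells (Homo sapiens) for inhibition, read by MTT assay, with a stated time of 48 h, tested at 10 uM (on this read-out lower numbers stand for less inhibition of growth and higher numbers for more inhibition of growth at the one concentration tested), compound 1 `Cc1cc(=O)c2c(O)cc(OC/C=C/c3ccccc3)c([C@H]3CCN(C)C[C@H]3O)c2o1` gives 9% and compound 2 `Cc1cc(=O)c2c(O)c(CN3CCC(N4CCCCC4)CC3)c(O)c([C@H]3CCN(C)C[C@H]3O)c2o1` gives 31% while compound 3 `Cc1cc(=O)c2c(O)c(CN3CCN(C(=O)OC(C)(C)C)CC3)c(O)c([C@H]3CCN(C)C[C@H]3O)c2o1` gives 21% under the same conditions. That places compound 3 within the scatter of compound 2 and beyond the scatter above compound 1. Compound 4 `CCOC(=O)N1CCN(Cc2c(O)c([C@H]3CCN(C)C[C@H]3O)c3oc(C)cc(=O)c3c2O)CC1` has not been measured yet. It differs from compound 3 in one place: ethyl in place of tert-butyl on an oxygen next to a carbonyl group with ethyl in place of tert-butyl on an oxygen next to a carbonyl group. Going by the values given here, no measured pair differs in one place only, so the data show no direct step for this change. Even compound 2 at 31% and compound 3 at 21% stay within the scatter of each other, although their structures differ by much more than this swap. No step beyond the scatter is therefore expected in this assay and neither direction is favoured. The estimated step of a number 1 percentage points lower from compound 3 to compound 4 (within the scatter) is expected to stay within the scatter. For compound 4 the estimate is 20% with an expected range from 9% to 32% in this measurement.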

Compound 4, percent growth inhibition at one concentration: 18%
Estimate against measurement, compound 4: 2 percentage points above, and the stated range covers the measured number.
By their numbers in this assay, from the lowest: compounds 1, 4, 3 and 2 (each within the scatter of the next, the first and the last beyond it).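

The first direct read of this change comes from this assay: ethyl in place of tert-butyl on an oxygen next to a carbonyl group gives a number 3 percentage points lower from compound 3 to compound 4 (within the scatter) as its step. Shrinking this group from four carbons to two, with no ring, charge or hydrogen-bond donor or acceptor entering or leaving, therefore produces no step that can be told from the usual spread of repeat measurements. Nothing available explains this outcome.

With only tert-butyl and ethyl compared here, the data leave open whether other groups on this oxygen, such as benzyl or a longer chain like n-hexyl, would stay within the scatter. Removing the whole ethoxycarbonyl group to leave a free amine on the ring is equally untested by these compounds.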